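Growth inhibition series: naphthyl to methoxyphenyl on the amine arm

This account rests on a few compounds, and the source may have more. Where it says the series, first, only, none or still open, it means among the compounds named here.

Measured compounds:
compound 1 `O=S(=O)(NCCCCNCc1ccc(Br)cc1)c1cc(C(F)(F)F)cc(C(F)(F)F)c1`: 1900 nM
compound 2 `O=S(=O)(NCCCNCc1cccc2ccccc12)c1cc(C(F)(F)F)cc(C(F)(F)F)c1`: 2700 nM

In a functional assay on Capan-2 cells (Homo sapiens) for inhibition, read by MTT assay, with a stated time of 72 h (on this read-out lower numbers stand for stronger inhibition of growth and higher numbers for weaker inhibition of growth), compound 1 gives 1900 nM and compound 2 gives 2700 nM. Compound 2 holds the higher of the two numbers, but its gap to compound 1 lies within the usual scatter, so no order between them can be read. For the measured compounds named here, the two compounds differ in more than one place, and no single step between measured compounds is available.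

Compound 3 `COc1ccc(CNCCCNS(=O)(=O)c2cc(C(F)(F)F)cc(C(F)(F)F)c2)cc1` is not yet measured. It differs from compound 2 by 4-methoxyphenyl in place of naphthalen-1-yl on a saturated chain carbon bound to an amine nitrogen. Going by the values given here, with no measured step of comparable kind to lean on, the expected change in this assay is small, in either direction or none beyond the scatter. The estimate for compound 3 is 3000 nM, with a range of 1200 nM to 7500 nM, meaning an expected step of a 1.1-fold higher number from compound 2 to compound 3 (0.05 log units; within the scatter).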

Compound 3, concentration for 50% growth inhibition: 2400 nM
The estimate for compound 3 lay 1.3-fold (0.10 log units) above the measured number; the range from low to high includes it.
By their numbers in this assay, from the lowest: compounds 1, 3 and 2 (each within the scatter of the next).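

In this assay the position gets its first single-place reading: 4-methoxyphenyl in place of naphthalen-1-yl (a 1.1-fold lower number from compound 2 to compound 3 (0.05 log units; within the scatter)) stays within the scatter, although one six-membered aromatic ring of carbon only and one hydrogen-bond acceptor replace two such rings and no acceptor. The change of (4-methoxybenzyl)amino in place of ((4-bromobenzyl)amino)methyl on a saturated chain carbon (a 1.3-fold higher number from compound 1 to compound 3 (0.10 log units; within the scatter)) also stays within the scatter, so compounds 1, 2 and 3 show no separation on this read-out. Nothing at hand accounts for this result.

As far as these compounds go, whether any group on this arm can move the number beyond the scatter remains open, since all three compounds carry a neutral aromatic ring there. A carboxylic acid, a pyridine ring or a cyclohexyl ring in that place would test this.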